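Removing a Methoxy Group from a Trifluoromethyl-Bearing Core

This account rests on a few compounds, and the source may have more. Where it says the series, first, only, none or still open, it means among the compounds named here.

Compound 1 `Oc1ccc(-c2nc3cc(Cl)c(Cl)cc3[nH]2)cc1`, compound 2 `COc1cc(OC)cc(-c2nc3cc(C(F)(F)F)ccc3[nH]2)c1` and compound 3 `COc1cc(-c2nc3cc(C(F)(F)F)ccc3[nH]2)cc(OC)c1OC` were examined in an ADME assay on BHK cells (Mesocricetus auratus) for cytotoxicity, read by MTT assay, with a stated time of 96 h; a lower number here means that less compound is tolerated, a higher number that more compound is tolerated. Compound 1 gives 29000 nM in this assay. Compound 3 gives 31000 nM in this assay. For compound 2 this assay reports only a limit, > 100000 nM. Compound 2 therefore stands at the edge of what the assay can report, as shown by the limit of > 100000 nM in this assay, at which 1 of the 3 values shown sits, and its place among the numbers is known only as a bound. For the measured compounds named here, the single measured step, an at least 3.2-fold lower number from compound 2 to compound 3 (0.50 log units; beyond the scatter), shows that methoxy in place of hydrogen on an aromatic carbon carried the number off that limit. Compound 4 `COc1cccc(-c2nc3cc(C(F)(F)F)ccc3[nH]2)c1`, not yet measured, differs from compound 2 by hydrogen in place of methoxy on an aromatic carbon. This change runs in the opposite sense to the measured step, so the measured step offers no reason to expect a number below the limit. Compound 4 is expected to give about 110000 nM in this assay, within 40000 nM to 300000 nM. The expected step that the limit leaves unreadable from compound 2 to compound 4 is accordingly estimated to be small.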

Compound 4, half-maximal cytotoxic concentration: 90000 nM
Compound 4: the middle estimate sits 1.2-fold (0.09 log units) above what was measured; low and high end bracket the measured number.
By their numbers in this assay, from the lowest: compounds 1 and 3 (each within the scatter of the next); then compound 4. At a limit, above all of these: compound 2.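

With hydrogen in place of methoxy on this aromatic carbon, this assay returns a measured number rather than a limit, and the change reads as an at least 1.1-fold lower number from compound 2 to compound 4 (0.04 log units; that floor lies within the scatter). Unlike the earlier step, an at least 3.2-fold lower number from compound 2 to compound 3 (0.50 log units; beyond the scatter), this removal of a methoxy group is not shown to move the number beyond the scatter, though its floor does not rule out a larger step. For compound 2 the assay gives only a limit, > 100000 nM, so the full size of this change cannot be read: the limit of > 100000 nM in this assay, at which 1 of the 4 values shown sits.

As far as these compounds go, how far compound 2 actually lies past its limit remains open. Also open, from the compounds shown here alone, is how an amine, a carboxylic acid or a longer chain such as ethoxy on this aromatic carbon would read in this assay.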